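From Benzyloxy to 5-Fluoro-2-hydroxyphenyl

The source may hold more compounds than are shown below. What is called first, only, known or untested is meant among the compounds shown, and "the series" means these compounds.

In a functional assay on V79-379A cells (Cricetulus griseus) for cytotoxicity, read by MTT assay, in the presence of a further agent that is not named here (a higher number here means a weaker inhibitor, a lower number a stronger inhibitor), compound 1 (`COC1=CC(=O)c2c(c(COC(=O)c3ccc(F)cc3)c(C)n2C)C1=O`) gives 27000 nM and compound 3 (`COC1=CC(=O)c2c(c(COc3c(Cl)cc(Cl)cc3Cl)cn2C)C1=O`) gives 700 nM while compound 2 (`COC1=CC(=O)c2c(c(COCc3ccccc3)c(C)n2C)C1=O`) gives 225000 nM as the highest number of the three. That makes compound 2 the weakest inhibitor here, with both gaps beyond the scatter. Compound 4 (`COC1=CC(=O)c2c(c(Cc3cc(F)ccc3O)c(C)n2C)C1=O`) is still unmeasured. Compared with compound 2, it has 5-fluoro-2-hydroxyphenyl in place of benzyloxy on a saturated chain carbon bound to an aromatic carbon. Among the compounds with values here, no measured pair shows this change alone, so any expectation is loose. Compound 2 at 225000 nM has both other compounds well below it. A moderate move to a lower number, beyond the scatter, is therefore expected (a 5.6-fold lower number from compound 2 to compound 4 (0.75 log units; beyond the scatter)). Compound 4 is expected at 40000 nM (estimated range 6000 nM to 200000 nM).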

Compound 4, half-maximal inhibitory concentration: 200000 nM
The estimate for compound 4 lay 5.0-fold (0.70 log units) below the measured number; measured number inside the range.
By their numbers in this assay, from the lowest: compound 3; then compound 1; then compounds 4 and 2 (each within the scatter of the next).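

In this assay, replacing benzyloxy with 5-fluoro-2-hydroxyphenyl gives a 1.1-fold lower number from compound 2 to compound 4 (0.05 log units; within the scatter) and so leaves the number effectively unchanged. The entering group adds a hydrogen-bond donor and a fluorine, yet this pair shows no shift beyond the scatter. No measurement at hand offers an explanation for this flat result. As far as these compounds go, it remains open whether the hydroxyl or the fluorine would have any effect alone, since both enter together. From the compounds shown here alone, it also remains open whether an amine or a carboxylic acid at this place would change the number.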